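Three limits and a fluoro swap

The source may hold more compounds than are shown below. What is called first, only, known or untested is meant among the compounds shown, and "the series" means these compounds.

Compound 1 `Cc1[nH]c2ccccc2c(=O)c1/C=C/c1ccc(O)cc1`: > 36100 nM (a limit)
Compound 2 `COc1ccc2[nH]c(C)c(Br)c(=O)c2c1`: > 37300 nM (a limit)
Compound 3 `CCCCC#Cc1c(C)[nH]c2ccc(OC)cc2c1=O`: > 36800 nM (a limit)

In an ADME assay on J774 cells (Mus musculus) for cytotoxicity (on this read-out higher numbers stand for an effect only at larger amounts of compound and lower numbers for an effect already at smaller amounts), compound 3 gives > 36800 nM, which is a limit and not a number. Compound 1 also gives only a limit, > 36100 nM. Compound 2 gives a limit too, > 37300 nM. Compound 3 therefore has no exact place among the three, and none of them can be ranked against another.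

The next compound, compound 4 `CCCCC#Cc1c(C)[nH]c2ccc(F)cc2c1=O`, keeps the hex-1-yn-1-yl group of compound 3 and carries fluoro in place of methoxy on an aromatic carbon. Among the measured compounds shown here, no measured step covers this exchange. The nearest one is a step that the two limits leave unreadable from compound 2 to compound 3, and it concerns a different pair of groups. It gives no size to carry over, and no measured number in this set shows a change in this assay. No step beyond the scatter is therefore expected, and compound 4 will probably report a limit as well. The expected step is an at least 1.0-fold lower number from compound 3 to compound 4 (0.03 log units; that floor lies within the scatter), and it is only a rough estimate. For compound 4 the estimated value is 34000 nM, with an expected range from 13000 nM to 39000 nM.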

Compound 4, half-maximal effective concentration: > 38600 nM
Compound 4: a limit, no number; the forecaster's own chance of this, stated with the estimate: 80%; at least 1.1-fold (0.05 log units) between middle value and limit.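

Compound 3 and compound 4 both give only limits in this assay, so no step can be read between them, and fluoro in place of methoxy gets no size. The compounds shown leave open at what concentration any of them would start to harm these cells, and whether this exchange shifts that concentration at all.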